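Swapping nitro for fluoro on a chromone side chain

The source may report more compounds than this note shows. Statements on the series, on what has been measured and on what is new or still open speak of the compounds shown alone.

Of the compounds shown here, three sharing one core have been tested in a functional assay on PC-3 cells (Homo sapiens) for inhibition, read by MTT assay, with a stated time of 48 h, tested at 10 uM; on this read-out lower numbers stand for less inhibition of growth and higher numbers for more inhibition of growth at the one concentration tested. Compound 2 `Cc1oc2c([C@H]3CCN(C)C[C@H]3O)c(O)cc(O)c2c(=O)c1C(O)c1ccc([N+](=O)[O-])cc1` gives 24%. Compound 1 `Cc1cc(=O)c2c(O)c(CN3CCC(N4CCCCC4)CC3)c(O)c([C@H]3CCN(C)C[C@H]3O)c2o1` gives 17%, a number that lies within the usual scatter of that of compound 2, so the two cannot be told apart on this read-out. Compound 3 `CCCCCCCCCC/C=C/c1c(C)oc2c([C@H]3CCN(C)C[C@H]3O)c(O)cc(O)c2c1=O` gives 0%, which sits beyond the scatter below compound 2. Compound 2 thus carries the largest of the three numbers, while being indistinguishable from compound 1.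

Compound 4 `Cc1oc2c([C@H]3CCN(C)C[C@H]3O)c(O)cc(O)c2c(=O)c1C(O)c1ccc(F)cc1` has not yet been measured. It differs from compound 2 in one place: fluoro in place of nitro on an aromatic carbon. Among the measured compounds shown here, no pair of measured compounds shows how such a change moves the read-out, so no direction can be drawn from the numbers at hand. The step from compound 2 to compound 4 is therefore expected to be small, a number 4 percentage points lower from compound 2 to compound 4 (within the scatter), within the usual scatter. Compound 4 is estimated at 20%, most likely between 5% and 35%.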

Compound 4, percent growth inhibition at one concentration: 0%
Beside the measured number, compound 4's estimate is 20 percentage points above it; measured number outside the range, below it.
By their numbers in this assay, from the lowest: compounds 3 and 4 (each within the scatter of the next); then compounds 1 and 2 (each within the scatter of the next).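

In this assay, among the compounds shown here, the change from 4-nitrophenyl to 4-fluorophenyl gives the first comparison in this set in which only one place differs: a number 24 percentage points lower from compound 2 to compound 4 (beyond the scatter). The rest of the molecule is the same in both compounds, so this step belongs to the swap alone, and the group on this aromatic carbon is not a silent spectator in this read-out. What is seen, however, is only that nitro and fluoro can be told apart here, and no measurement shown explains why they differ.

As far as these compounds go, with just two groups at this place, it remains open whether nitro adds to the growth inhibition or fluoro takes it away. An amine, a nitrile or a plain hydrogen at the same carbon could show which compound it resembles, compound 2 or compound 4.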